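The source may report more compounds than this note shows. Statements on the series, on what has been measured and on what is new or still open speak of the compounds shown alone.

In a functional assay on K562 cells (Homo sapiens) for inhibition, read by trypan blue exclusion, with a stated time of 72 h (a lower number here means a stronger inhibitor, a higher number a weaker inhibitor), compound 1 (`Cn1c(=O)c(S(=O)(=O)c2ccc(Cl)cc2Cl)cc2cnc(Nc3ccc4[nH]ccc4c3)nc21`) gives 1000 nM, while compound 2 (`Cn1c(=O)c(S(=O)(=O)Nc2ccc(F)cc2F)cc2cnc(Nc3ccc4[nH]ccc4c3)nc21`) gives 5000 nM. Compound 2 therefore holds the higher number of the two, making it the weaker inhibitor of the pair. Compound 3 (`Cn1c(=O)c(S(=O)(=O)c2ccc([N+](=O)[O-])cc2F)cc2cnc(Nc3ccc4[nH]ccc4c3)nc21`) has 2-fluoro-4-nitrophenyl in place of (2,4-difluorophenyl)amino on a sulfonyl sulfur. Going by the values given here, only one measured step bears on this change: a 5.0-fold higher number from compound 1 to compound 2 (0.70 log units; beyond the scatter), which exchanged 2,4-dichlorophenyl for (2,4-difluorophenyl)amino at the same place. Among the compounds with values here, compound 3 reverses that kind of exchange, but no measured compound carries 2-fluoro-4-nitrophenyl, so the single modest step gives only a rough guide. A step of similar size towards a lower number is expected in this assay, stated as a 5.0-fold lower number from compound 2 to compound 3 (0.70 log units; beyond the scatter). The estimated value for compound 3 is 1000 nM, with an expected range of 300 nM to 3500 nM.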

Compound 3, half-maximal inhibitory concentration: 200 nM
The estimate for compound 3 lay 5.0-fold (0.70 log units) above the measured number, and the stated range ends above it.
By their numbers in this assay, from the lowest: compound 3; then compound 1; then compound 2.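

In this assay, the sulfonyl sulfur position proves more sensitive than the earlier pair suggested, with a 25-fold lower number from compound 2 to compound 3 (1.40 log units; beyond the scatter) for replacing (2,4-difluorophenyl)amino with 2-fluoro-4-nitrophenyl. The amino link is not the only feature that matters here: with an aromatic carbon on the sulfonyl sulfur in both compounds, the ring change still gives a 5.0-fold lower number from compound 1 to compound 3 (0.70 log units; beyond the scatter), so 2-fluoro-4-nitrophenyl goes with the lowest number of the three. No measurement shown here explains either step.

Compound 3 differs from compound 1 in both ring substituents, so the shares of the nitro group and the fluorine cannot be separated. Going by these compounds, it also remains open whether a nitrile or a carboxylic acid in place of the nitro group would keep the number this low.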